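Sulfonamide nitrogen substituent and receptor agonism

The compounds below may be only part of what the source reports. "The series", "measured", "known", "first", "only" and "open" are said of these compounds alone.

compound 1 `O=C(NS(=O)(=O)c1ccc(NC(=O)c2ccc(Cl)cc2Cl)cc1)c1ccccc1`: > 100000 nM
compound 2 `O=C(Nc1ccc(S(=O)(=O)Nc2ccccc2)cc1)c1ccc(Cl)cc1Br`: 1020 nM
compound 3 `O=C(Nc1ccc(S(=O)(=O)Nc2ccccc2)cc1)c1ccc(I)cc1F`: 5130 nM

In a functional assay on HEK293 cells for agonist activity at probable G-protein coupled receptor 27 (Homo sapiens), read by a luciferase reporter and beta-arrestin recruitment, with a stated time of 10 min (on this read-out higher numbers stand for an effect only at larger amounts of compound and lower numbers for an effect already at smaller amounts), compound 1 reaches only a limit, > 100000 nM, which is the limit of > 100000 nM in this assay, at which 1 of the 3 values shown sits. Among the compounds with values here, compound 2 gives 1020 nM and compound 3 gives 5130 nM; the one measured step, a 5.0-fold higher number from compound 2 to compound 3 (0.70 log units; beyond the scatter), concerns the group on a carbonyl carbon, not the sulfonamide nitrogen. Compound 4 `O=C(Nc1ccc(S(=O)(=O)Nc2ccccc2Cl)cc1)c1ccc(Cl)cc1Cl` differs from compound 1 at that nitrogen: 2-chlorophenyl in place of benzoyl on a sulfonamide nitrogen. Within the data shown here, no measured step covers this change. Compound 2 and compound 3 both lack a benzoyl on the sulfonamide nitrogen and both give numbers within the assay; compound 4 shares that feature, so a move from the limit into the measured range is expected, with wide uncertainty. For compound 4 the estimate is 3000 nM, with a range from 500 nM to 30000 nM. From the limit this means an expected step of an at least 33-fold lower number from compound 1 to compound 4 (1.52 log units; beyond the scatter).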

Compound 4, half-maximal effective concentration: 1260 nM
Beside the measured number, compound 4's estimate is 2.4-fold (0.38 log units) above it; low and high end bracket the measured number.
By their numbers in this assay, from the lowest: compounds 2 and 4 (each within the scatter of the next); then compound 3. At a limit, above all of these: compound 1.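

Exchanging benzoyl for 2-chlorophenyl on the sulfonamide nitrogen gives, in this assay, an at least 79-fold lower number from compound 1 to compound 4 (1.89 log units; beyond the scatter). This position can therefore carry a compound from a limit into the measured range, whereas the earlier change on the carbonyl carbon, a 5.0-fold higher number from compound 2 to compound 3 (0.70 log units; beyond the scatter), stayed within that range. The step from compound 1 is only a bound, since compound 1 stands at a limit: the limit of > 100000 nM in this assay, at which 1 of the 4 values shown sits.

Going by these compounds, whether the carbonyl of benzoyl is what matters stays open; an acetyl or a methyl on that nitrogen would bear on this. Also open, on these data alone, is how plain phenyl compares with 2-chlorophenyl there, with the rest of compound 4 held fixed.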